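Phenyl for Hydroxymethoxyphenyl: Expected Cytotoxicity on Vero Cells

This account rests on a few compounds, and the source may have more. Where it says the series, first, only, none or still open, it means among the compounds named here.

Compound 3 `CCn1cc(C(=O)N2N=C(c3cc4ccccc4o3)CC2c2ccc(OC)cc2O)c(=O)c2ccc(C)nc21` stands only at a limit in an ADME assay on Vero cells (Chlorocebus sabaeus) for cytotoxicity, read by MTT assay, with a stated time of 72 h; a lower number here means a stronger inhibitor, a higher number a weaker inhibitor. In this assay compound 3 gives > 154000 nM, which is a limit of the assay and not a number. The two other values are limits too. Compound 1 `COc1ccc(C2CC(c3cc4ccccc4o3)=NN2C(=O)c2ccncc2)c(O)c1` gives > 190000 nM, a limit. Compound 2 `COc1ccc(C2CC(c3cc4ccccc4o3)=NN2C(=O)c2ccncc2)cc1` gives > 200000 nM, also a limit. The step that the two limits leave unreadable from compound 1 to compound 2 therefore cannot be read. Compound 4 `CCn1cc(C(=O)N2N=C(c3cc4ccccc4o3)CC2c2ccccc2)c(=O)c2ccc(C)nc21` differs from compound 3 by phenyl in place of 2-hydroxy-4-methoxyphenyl on a saturated ring carbon. All three values sit at limits: the limit of > 154000 nM in this assay, at which 1 of the 3 values shown sits, the limit of > 190000 nM in this assay, at which 1 of the 3 values shown sits, and (the limit of > 200000 nM in this assay, at which 1 of the 3 values shown sits). For the measured compounds named here, no measured step bears on this change. The step is expected to be a step that the limit leaves unreadable from compound 3 to compound 4, no movement beyond the scatter. Compound 4 is expected to give 200000 nM, between 100000 nM and 400000 nM, most likely again only a limit.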

Compound 4, half-maximal inhibitory concentration: > 210000 nM
Compound 4: only a limit was reported (the forecaster's own chance of this, stated with the estimate: 85%); at least 1.0-fold (0.02 log units) between middle value and limit.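

Compound 3 and compound 4 are both reported only as limits, and the step between them cannot be read. The compounds shown leave open at what concentration any of them would harm the cells.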